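Replacing 4-Methylphenyl with 3-Iodophenyl

The compounds below may be only part of what the source reports. "The series", "measured", "known", "first", "only" and "open" are said of these compounds alone.

Among the compounds with values here, in a functional assay on HCT-116 cells (Homo sapiens) for antiproliferative activity, read by MTT assay, with a stated time of 72 h (on this read-out lower numbers stand for stronger inhibition and higher numbers for weaker inhibition), compound 2 (`Cc1ccc(NC(=O)CCc2cccc3c2B(O)OC3)cc1`) gives 4500 nM, the lower of the two numbers so far, while compound 1 (`O=C(CCc1cccc2c1B(O)OC2)Nc1ccc(Cl)cc1`) gives 12000 nM. Compound 3 (`O=C(CCc1cccc2c1B(O)OC2)Nc1cccc(I)c1`) brings a new change: 3-iodophenyl in place of 4-methylphenyl on an amide-type nitrogen. Within the data shown here, the only measured step that offers guidance is a 2.7-fold lower number from compound 1 to compound 2 (0.43 log units; beyond the scatter), a modest change seen with methyl in place of chloro. Among the measured compounds shown here, no measured compound carries iodine, so this guidance is loose. The expected step is no larger and points toward weaker inhibition: a 1.6-fold higher number from compound 2 to compound 3 (0.19 log units; within the scatter). For compound 3, the estimated value is 7000 nM, with an expected range of 2000 nM to 20000 nM.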

Compound 3, half-maximal inhibitory concentration: 2300 nM
For compound 3 the middle estimate is 3.0-fold (0.48 log units) above the measured one; low and high end bracket the measured number.
By their numbers in this assay, from the lowest: compounds 3 and 2 (each within the scatter of the next); then compound 1.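

In this assay, 3-iodophenyl on the amide-type nitrogen gives a 2.0-fold lower number from compound 2 to compound 3 (0.29 log units; within the scatter), so this change cannot be told apart from no change. Against the 4-chlorophenyl group, it gives a 5.2-fold lower number from compound 1 to compound 3 (0.72 log units; beyond the scatter), a real separation, which shows that this position accepts an iodine-bearing phenyl ring. Nothing measured here explains either step.

Because iodine and its place on the ring both differ between compound 1 and compound 3, the compounds shown cannot separate those two changes. As far as these compounds go, how an amine or a carboxylic acid on this phenyl ring would read also stays open.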